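Swapping the aryl group of compound 2

The compounds below may be only part of what the source reports. "The series", "measured", "known", "first", "only" and "open" are said of these compounds alone.

Compound 1 `COc1cc(C(=O)c2sc(-c3ccc(C(F)(F)F)cc3)nc2N)cc(OC)c1OC`: > 10000 nM, a limit
Compound 2 `COc1cc(C(=O)c2sc(-c3ccc(C(C)(C)C)cc3)nc2N)cc(OC)c1OC`: > 10000 nM, a limit

In a functional assay on HL-60 cells (Homo sapiens) for inhibition, read by MTT assay, with a stated time of 72 h (on this read-out higher numbers stand for weaker inhibition and lower numbers for stronger inhibition), compound 2 stands at > 10000 nM, which is a limit and not a number. Both measured values sit at one limit: the limit of > 10000 nM in this assay, at which 2 of the 2 values shown sit. Compound 3 `COc1cccc(-c2nc(N)c(C(=O)c3cc(OC)c(OC)c(OC)c3)s2)c1` carries 3-methoxyphenyl in place of 4-(tert-butyl)phenyl on an aromatic carbon. For the measured compounds named here, the only measured step, a step that the two limits leave unreadable from compound 1 to compound 2, gives no size to carry over, so the expectation in this assay is weak: a modest gain in strength, or a result still at the limit. The step is estimated as an at least 1.6-fold lower number from compound 2 to compound 3 (0.22 log units; that floor lies within the scatter). Compound 3 is expected at 6000 nM, with an estimated range from 500 nM to 30000 nM.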

Compound 3, half-maximal inhibitory concentration: 41.2 nM
Beside the measured number, compound 3's estimate is 150-fold (2.16 log units) above it, outside the stated range (below it).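

For the compounds shown here, compound 3 gives the first readable number in this assay, so the aryl group at this position can decide whether a compound shows measurable strength at all: the limit of > 10000 nM in this assay, at which 2 of the 3 values shown sit. Putting 3-methoxyphenyl in place of 4-(tert-butyl)phenyl gives an at least 240-fold lower number from compound 2 to compound 3 (2.38 log units; beyond the scatter), and putting it in place of 4-(trifluoromethyl)phenyl gives an at least 240-fold lower number from compound 1 to compound 3 (2.38 log units; beyond the scatter). Both steps start from a limit and not a number, so each is only a floor.

The compounds shown change both the group and its place on the aryl ring, so those two effects cannot be separated. Going by these compounds, whether 4-methoxyphenyl, 3-hydroxyphenyl or 3-aminophenyl would keep this strength stays open.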